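Replacing the aryl group on the shared core

This account rests on a few compounds, and the source may have more. Where it says the series, first, only, none or still open, it means among the compounds named here.

Values in a functional assay on HeLa cells (Homo sapiens) for inhibition, read by CCK-8 assay, with a stated time of 48 h; a lower number here means a stronger inhibitor, a higher number a weaker inhibitor:
- compound 1 `COc1cc(-c2ccnc3cc(-c4ccc(F)cc4)nn23)cc(OC)c1OC` gives 5840 nM
- compound 2 `COc1cc(-c2ccnc3cc(-c4ccc(C)cc4)nn23)cc(OC)c1OC` gives 21 nM

Of the two measured compounds, compound 2 holds the lower number at 21 nM in this assay. Compound 3 `COc1cc(-c2ccnc3cc(-c4cccc(C#N)c4)nn23)cc(OC)c1OC` has 3-cyanophenyl in place of 4-methylphenyl on an aromatic carbon of a five-membered aromatic ring with 2 nitrogen. The full change is 3-cyanophenyl in place of 4-methylphenyl on an aromatic carbon (the rest of the structure stays the same).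

Within the data shown here, only one measured step bears on this change, and it is large: a 280-fold lower number from compound 1 to compound 2 (2.44 log units; beyond the scatter) for methyl in place of fluoro on an aromatic carbon. Among the measured compounds shown here, that step shows how far a single substituent on this aryl group can move the number, and compound 2 is the only measured compound with a low value. No nitrile has been measured, so the size of the change is uncertain. A clear rise is expected, probably smaller than the measured step. The estimate is a 19-fold higher number from compound 2 to compound 3 (1.28 log units; beyond the scatter). Compound 3 is expected at 400 nM, within an estimated range of 40 nM to 4000 nM.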

Compound 3, half-maximal inhibitory concentration: > 10000 nM
Compound 3 gave a limit, no number; the forecaster's own chance of this, stated with the estimate: 3%; at least 25-fold (1.39 log units) between middle value and limit.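

Compound 3 reads as a limit and not as a number in this assay: the limit of > 10000 nM in this assay, at which 1 of the 3 values shown sits.

The change to 3-cyanophenyl gives an at least 470-fold higher number from compound 2 to compound 3 (2.67 log units; beyond the scatter), so the low value at this position does not survive this replacement of the aryl group, and among the three compounds shown only compound 2, with 4-methylphenyl, holds a low number. The comparison with the fluoro compound gives an at least 1.7-fold higher number from compound 1 to compound 3 (0.23 log units; that floor lies within the scatter); that floor lies within the scatter, so 3-cyanophenyl and 4-fluorophenyl cannot be put in order from these data.

The step from compound 2 to compound 3 changes both the substituent and where it sits on the phenyl ring, so the compounds shown cannot separate the effect of the nitrile from that of its placement; 4-cyanophenyl and 3-methylphenyl would divide the two. Also open, going by these compounds, is whether the low number depends on methyl itself or extends to groups such as 4-ethylphenyl, 4-methoxyphenyl or 4-aminophenyl.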